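Swapping the hydrazone aryl group on a shared triazine core

The source may hold more compounds than are shown below. What is called first, only, known or untested is meant among the compounds shown, and "the series" means these compounds.

Of the compounds shown here, two sharing one core have been measured so far. Compound 1 `NS(=O)(=O)c1ccc(Nc2nc(N/N=C/c3ccc(C(F)(F)F)cc3)nc(Nc3ccccc3)n2)cc1` gives 3110 nM in a functional assay on A549 cells (Homo sapiens) for inhibition, read by sulforhodamine B assay, with a stated time of 48 h; a higher number here means a weaker inhibitor of growth, a lower number a stronger inhibitor of growth. Compound 2 `Cc1nn(-c2ccccc2)cc1/C=N/Nc1nc(Nc2ccccc2)nc(Nc2ccc(S(N)(=O)=O)cc2)n1` gives 1850 nM in this assay, the lower of the two numbers, though the step of a 1.7-fold lower number from compound 1 to compound 2 (0.23 log units; within the scatter) is within the scatter. Compound 3 `NS(=O)(=O)c1ccc(Nc2nc(N/N=C/c3ccccn3)nc(Nc3ccccc3)n2)cc1` is not yet measured; it differs from compound 2 by pyridin-2-yl in place of 3-methyl-1-phenyl-1H-pyrazol-4-yl on a carbon with a double bond to nitrogen. Among the measured compounds shown here, the only measured step that bears on this change is the one from compound 1 to compound 2, which also exchanged the aryl group on that same carbon, and that step was a 1.7-fold lower number from compound 1 to compound 2 (0.23 log units; within the scatter), too small to count. For the measured compounds named here, with one small step as the only guide, the change to compound 3 is expected to give no step beyond the scatter in this assay, with the expected step being a 1.4-fold higher number from compound 2 to compound 3 (0.13 log units; within the scatter). Compound 3 is therefore estimated at 2500 nM in this assay, within a range from 900 nM to 7000 nM.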

Compound 3, concentration for 50% growth inhibition: 2290 nM
For compound 3 the middle estimate is 1.1-fold (0.04 log units) above the measured one; low and high end bracket the measured number.
By their numbers in this assay, from the lowest: compounds 2, 3 and 1 (each within the scatter of the next).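

Putting pyridin-2-yl in place of 3-methyl-1-phenyl-1H-pyrazol-4-yl on the carbon with a double bond to nitrogen gave a 1.2-fold higher number from compound 2 to compound 3 (0.09 log units; within the scatter) in this assay, and putting it in place of 4-(trifluoromethyl)phenyl gave a 1.4-fold lower number from compound 1 to compound 3 (0.13 log units; within the scatter). The group at this place can therefore go from 12 heavy atoms to 6, and a ring with a hetero atom can stand in for the phenyl ring of compound 1, without a step beyond the scatter. Nothing available explains why these three groups read alike.

All three groups are aromatic rings, so the compounds shown leave open whether a group without a ring, such as an amine, a carboxylic acid or a longer alkyl chain, would give a step beyond the scatter. They also leave open how changes elsewhere on the shared core would read.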